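A second (4-nitrophenyl)carbonyl group on compound 3

The source may hold more compounds than are shown below. What is called first, only, known or untested is meant among the compounds shown, and "the series" means these compounds.

Values in a functional assay on NTUB1 cells (Homo sapiens) for cytotoxicity, read by MTT assay, with a stated time of 48 h; on this read-out lower numbers stand for stronger inhibition and higher numbers for weaker inhibition
Compound 1 `C=C1CC[C@@H]2[C@](C)(CO)[C@H](O)CC[C@@]2(C)[C@@H]1CCc1ccoc1` gives 39800 nM
Compound 2 `C=C1CC[C@@H]2[C@](C)(COC(=O)COc3ccccc3)[C@H](O)CC[C@@]2(C)[C@@H]1CCc1ccoc1` gives > 100000 nM, a limit and not a number
Compound 3 `C=C1CC[C@@H]2[C@](C)(COC(=O)c3ccc([N+](=O)[O-])cc3)[C@H](O)CC[C@@]2(C)[C@@H]1CCc1ccoc1` gives 23800 nM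

Compound 3 and compound 1 lie within the scatter of each other. Compound 4 `C=C1CC[C@@H]2[C@](C)(COC(=O)c3ccc([N+](=O)[O-])cc3)[C@H](OC(=O)c3ccc([N+](=O)[O-])cc3)CC[C@@]2(C)[C@@H]1CCc1ccoc1` has (4-nitrophenyl)carbonyl in place of hydrogen on an oxygen on a saturated carbon. The same group on a different oxygen gave only a 1.7-fold lower number from compound 1 to compound 3 (0.22 log units; within the scatter), whereas another acyl group gave an at least 2.5-fold higher number from compound 1 to compound 2 (0.40 log units; beyond the scatter), and swapping between the two gave an at least 4.2-fold lower number from compound 2 to compound 3 (0.62 log units; beyond the scatter). No step beyond the scatter is therefore expected in this assay, although a limit reading remains possible. The expected step is a 1.3-fold higher number from compound 3 to compound 4 (0.10 log units; within the scatter). The estimate for compound 4 is 30000 nM, with an expected range of 9000 nM to 100000 nM.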

Compound 4, half-maximal inhibitory concentration: > 100000 nM
Compound 4: only a limit was reported; the forecaster's own chance of this, stated with the estimate: 30%; middle value at least 3.3-fold (0.52 log units) away from the limit.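

In this assay, acylating the hydroxy on the saturated ring carbon gives an at least 4.2-fold higher number from compound 3 to compound 4 (0.62 log units; beyond the scatter). The same (4-nitrophenyl)carbonyl group on the other oxygen gave a 1.7-fold lower number from compound 1 to compound 3 (0.22 log units; within the scatter), so this group's effect depends on which oxygen carries it. The reading for compound 4 is a limit and not a number, and the true size of the step stays unknown: the limit of > 100000 nM in this assay, at which 2 of the 4 values shown sit.

Among these compounds, only one acyl group sits on this oxygen here, so the compounds cannot separate losing the free hydroxy from adding the large ester. An acetyl ester or an amine at this carbon remains untested among the compounds shown.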